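Testing a Chloro-Hydroxyphenyl Group on a Weak Series

This account rests on a few compounds, and the source may have more. Where it says the series, first, only, none or still open, it means among the compounds named here.

Measured so far:
compound 1 `COc1ccc(C(=O)/C=C/c2cccc(F)c2)c2c1C=CC(C)(C)O2` gives > 10000 nM in a functional assay on K562 cells (Homo sapiens) for antiproliferative activity, read by MTT assay, with a stated time of 24 h; a higher number here means a weaker inhibitor, a lower number a stronger inhibitor
compound 2 `COc1ccc(C(=O)/C=C/c2cccc([N+](=O)[O-])c2)c2c1C=CC(C)(C)O2` gives 5870 nM
compound 3 `COc1ccc(C(=O)/C=C/c2cccc3ccccc23)c2c1C=CC(C)(C)O2` gives > 10000 nM

The value for compound 1 is a limit of this assay, not a number; it sits at the limit of > 10000 nM in this assay, at which 2 of the 3 values shown sit. The value for compound 3 is likewise a limit. Only compound 2 gives a real number. For the measured compounds named here, the one measured step, an at least 1.7-fold lower number from compound 1 to compound 2 (0.23 log units; that floor lies within the scatter), shows that swapping the group on the aromatic ring can move the number, though its floor lies within the scatter.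

Compound 4 `COc1ccc(C(=O)/C=C/c2cc(Cl)ccc2O)c2c1C=CC(C)(C)O2` differs from compound 1 by 5-chloro-2-hydroxyphenyl in place of 3-fluorophenyl on a double-bonded chain carbon bound to a double-bonded chain carbon. Going by the values given here, no measured step involves a hydroxyl or a chloro group, so the only guidance is that the aryl change in compound 2 gave at most a modest shift. A small move toward a lower number is expected, an at least 1.2-fold lower number from compound 1 to compound 4 (0.09 log units; that floor lies within the scatter), but a limit remains quite possible. Compound 4 is estimated at 8000 nM, with a range from 2500 nM to 30000 nM.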

Compound 4, half-maximal inhibitory concentration: 5510 nM
For compound 4 the middle estimate is 1.5-fold (0.16 log units) above the measured one; the measured number falls inside the stated range.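

Compound 4 is the second compound here to give a real number rather than a limit, and its ring differs from the 3-nitrophenyl ring of compound 2. Replacing 3-fluorophenyl with 5-chloro-2-hydroxyphenyl gives an at least 1.8-fold lower number from compound 1 to compound 4 (0.25 log units; that floor lies within the scatter), and this size is only a floor, with compound 1 standing at a limit and not a number: the limit of > 10000 nM in this assay, at which 2 of the 4 values shown sit. The other step, a 1.1-fold lower number from compound 2 to compound 4 (0.03 log units; within the scatter), shows that these two different rings cannot be told apart in this assay.

The separate shares of the hydroxyl and the chloro group in the step from the 3-fluorophenyl ring remain open among the compounds shown. Also open, going by these compounds, is whether an amine or a carboxylic acid on this ring would give a clearly lower number.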